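Methyl in place of chloro: note toward compound 4

This account rests on a few compounds, and the source may have more. Where it says the series, first, only, none or still open, it means among the compounds named here.

Within the data shown here, the three measured members are compound 1 `CC(C)(C)c1ccc(OCCCON2C(N)=NC(N)=NC23CCSCC3)cc1`, compound 2 `NC1=NC2(CCOCC2)N(OCCCOc2ccc(Cl)cc2)C(N)=N1` and compound 3 `NC1=NC2(CCSCC2)N(OCCCOc2ccccc2Cl)C(N)=N1`. In a functional assay on HL-60 cells (Homo sapiens) for antiproliferative activity, read by MTT assay, with a stated time of 72 h (on this read-out lower numbers stand for stronger inhibition and higher numbers for weaker inhibition), compound 1 gives 280 nM, compound 2 gives 330 nM and compound 3 gives 390 nM; compound 2 holds the second highest of the three numbers, and its gaps to compound 1 and to compound 3 both lie within the scatter, so no order among the three can be read. Compound 4 `Cc1ccc(OCCCON2C(N)=NC(N)=NC23CCOCC3)cc1` is not yet measured. It differs from compound 2 as follows: methyl in place of chloro on an aromatic carbon. Among the measured compounds shown here, no step between measured compounds isolates this change, and the measured values sit close together, so in this assay a step no larger than the scatter is expected, in either direction. Compound 4 is expected to give 400 nM in this assay, within a range from 150 nM to 1100 nM. For compound 4 the expected step is a 1.2-fold higher number from compound 2 to compound 4 (0.08 log units; within the scatter).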

Compound 4, half-maximal inhibitory concentration: 2580 nM
The estimate for compound 4 lay 6.5-fold (0.81 log units) below the measured number, outside the stated range (above it).
By their numbers in this assay, from the lowest: compounds 1, 2 and 3 (each within the scatter of the next); then compound 4.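

In this assay the change from 4-chlorophenyl to 4-methylphenyl gives a 7.8-fold higher number from compound 2 to compound 4 (0.89 log units; beyond the scatter) and so shows that this position on the aromatic ring responds to the exchange of a single heavy atom. The earlier compounds shown here differ in more than one place and isolated no change, so they could not show this.

As far as these compounds go, whether the same step holds with other groups elsewhere in the molecule stays open, as does how fluoro, methoxy or an amine would read at this place. No measurement at hand offers a reason for the step.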